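Moving the Hydroxyl Around the Aryl Ring

This account rests on a few compounds, and the source may have more. Where it says the series, first, only, none or still open, it means among the compounds named here.

Two analogues built on one shared core have been tested in a functional assay on the whole organism (strain Swiss albino) with Mus musculus as the target, with a stated time of 4 h; a higher number here means that more compound is needed for the effect, a lower number that less compound is needed. Compound 1 `C=C(C)[C@@H]1CC=C(C)/C(=N/NC(=O)Nc2nnc(-c3ccc(Cl)cc3)o2)C1` carries a 4-chlorophenyl group on an aromatic carbon of the five-membered aromatic ring with 2 nitrogen and 1 oxygen, and compound 1 gives 300 mg/kg. Compound 2 `C=C(C)[C@@H]1CC=C(C)/C(=N/NC(=O)Nc2nnc(-c3ccccc3O)o2)C1` carries a 2-hydroxyphenyl group there instead, and compound 2 gives 300 mg/kg. The step of no change at the digits printed from compound 1 to compound 2 (within the scatter) shows that exchanging one aryl group for the other left the dose where it was, so compound 2 stands level with compound 1 on this measure.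

Compound 3 `C=C(C)[C@@H]1CC=C(C)/C(=N/NC(=O)Nc2nnc(-c3ccc(O)cc3)o2)C1` has not yet been measured. It differs from compound 2 only as shown by 4-hydroxyphenyl in place of 2-hydroxyphenyl on an aromatic carbon. For the measured compounds named here, no measured step covers this exact exchange; the one step that bears on it, the flat one from compound 1 to compound 2, also swapped the aryl group on that same aromatic carbon. On that basis no change beyond the scatter is expected in this assay, in either direction. Compound 3 is therefore estimated at 300 mg/kg, with a range from 100 mg/kg to 1000 mg/kg. The expected step is no change at the digits printed from compound 2 to compound 3 (within the scatter).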

Compound 3, minimum effective dose: 300 mg/kg
Estimate against measurement, compound 3: no gap at the digits printed; the measured number falls inside the stated range.
By their numbers in this assay, from the lowest: compounds 1, 2 and 3 (each within the scatter of the next).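

In this assay, the new result separates two things the earlier pair could not: that pair changed both the substituent and where it sat on the aryl ring, whereas here the same atoms are simply joined differently. Swapping 2-hydroxyphenyl for 4-hydroxyphenyl on the aromatic carbon of the five-membered ring gives no change at the digits printed from compound 2 to compound 3 (within the scatter), so this placement of the hydroxy group makes no visible difference to the dose, and hydroxy in place of chloro at the same spot on the aryl ring gives no change at the digits printed from compound 1 to compound 3 (within the scatter), so that exchange also leaves the dose unmoved. No measurement is available to explain why these changes leave the dose flat.

On these data alone, all three compounds carry a substituted phenyl group at this position, so it remains open whether the dose would shift with something other than a phenyl ring there, such as a butyl chain, or with a phenyl ring bearing an amine or a carboxylic acid. The compounds shown also leave open whether any change on the shared core outside this aryl group would alter the dose.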